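The compounds below may be only part of what the source reports. "The series", "measured", "known", "first", "only" and "open" are said of these compounds alone.

Two macrocyclic compounds share a core and differ in one side group. Compound 1 `CCC[C@@H]1NC(=O)[C@@H](C(C)C)NC(=O)[C@@H](c2ccccc2)NCCOc2ccccc2CCCNC1=O` carries a phenyl on a saturated ring carbon. In an assay on isolated protein for displacement of a labelled ligand from Motilin receptor (Homo sapiens) (a lower number here means a stronger inhibitor, a higher number a weaker inhibitor), compound 1 reaches only > 10000 nM, which is a limit of the assay rather than a number. Compound 2 `CCC[C@@H]1NC(=O)[C@@H](C(C)C)NC(=O)[C@@H](Cc2csc3ccccc23)NCCOc2ccccc2CCCNC1=O` carries a (1-benzothiophen-3-yl)methyl at that place instead, and in this assay compound 2 gives 11 nM, the only number shown here. That exchange gave an at least 900-fold lower number from compound 1 to compound 2 (2.95 log units; beyond the scatter), measured against (the limit of > 10000 nM in this assay, at which 1 of the 2 values shown sits). Compound 3 `CCC[C@@H]1NC(=O)[C@@H](C(C)C)NC(=O)[C@@H](Cc2cccc3ccccc23)NCCOc2ccccc2CCCNC1=O` keeps the methyl-linked arm and swaps only the ring system: naphthalen-1-yl in place of 1-benzothiophen-3-yl on a saturated chain carbon bound to a saturated ring carbon. Both compound 2 and compound 3 carry a two-ring aromatic arm, whereas the measured step concerns the jump from bare phenyl to such an arm, so no step beyond the scatter is expected, a 1.4-fold higher number from compound 2 to compound 3 (0.13 log units; within the scatter). Compound 3 is therefore estimated at 15 nM, within 4 nM to 60 nM.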

Compound 3, inhibition constant: 8.3 nM
Beside the measured number, compound 3's estimate is 1.8-fold (0.26 log units) above it, within the range that was stated.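

In this assay, two different two-ring aromatic arms on the methyl link cannot be told apart: a 1.3-fold lower number from compound 2 to compound 3 (0.12 log units; within the scatter). The sulfur atom of 1-benzothiophen-3-yl can thus be replaced by the all-carbon naphthalen-1-yl with no change beyond the scatter, and the large step away from the bare phenyl now appears with a second arm, an at least 1200-fold lower number from compound 1 to compound 3 (3.08 log units; beyond the scatter). For compound 1 the starting point of that step is a limit of the assay and not a number: the limit of > 10000 nM in this assay, at which 1 of the 3 values shown sits.

Both arms differ from the phenyl of compound 1 in the methyl link and in the second ring together, so a benzyl arm would be needed to tell which of the two matters. Also open, going by these compounds, is how this place would respond to an arm carrying an amine or a carboxylic acid, or to a longer chain before the naphthalen-1-yl.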